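The source may hold more compounds than are shown below. What is called first, only, known or untested is meant among the compounds shown, and "the series" means these compounds.

Two compounds have numbers in a functional assay on A549 cells (Homo sapiens) for antiproliferative activity, read by MTT assay, with a stated time of 48 h; a lower number here means a stronger inhibitor, a higher number a weaker inhibitor. Compound 1 `O=C(/C=C/c1ccc(C(F)(F)F)cc1)Nc1nnc(-c2ccc(Br)cc2)s1` gives 4.68 ug/mL in this assay, while compound 2 `Cc1ccc(/C=C/C(=O)Nc2nnc(-c3ccc(C)cc3)s2)cc1` gives 1.08 ug/mL, the lowest of the two numbers shown and separated from compound 1 by a gap that lies beyond the scatter. Compound 3 `Cc1ccc(/C=C/C(=O)Nc2nnc(-c3ccc(Br)cc3)s2)cc1` has not yet been measured; it differs from compound 2 by bromo in place of methyl on an aromatic carbon. Among the compounds with values here, no measured pair isolates this change, so its size is uncertain. The step is expected to be a modest weakening, a 1.9-fold higher number from compound 2 to compound 3 (0.27 log units; within the scatter). For compound 3 the estimate in this assay is 2 ug/mL, with a range from 0.8 ug/mL to 5 ug/mL.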

Compound 3, half-maximal inhibitory concentration: 1.51 ug/mL
Compound 3: middle estimate off by 1.3-fold (0.12 log units), on the high side; the measured number falls inside the stated range.
By their numbers in this assay, from the lowest: compounds 2 and 3 (each within the scatter of the next); then compound 1.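

In this assay the change from 4-methylphenyl to 4-bromophenyl gives a 1.4-fold higher number from compound 2 to compound 3 (0.15 log units; within the scatter) and so leaves the two groups indistinguishable at this position. Within the data shown here, with that bromo held constant, methyl in place of trifluoromethyl on an aromatic carbon gives a 3.1-fold lower number from compound 1 to compound 3 (0.49 log units; beyond the scatter) and is the first single-place change here to exceed the scatter. No measurement offered here explains either step. On these data alone, whether an amine, a methoxy group or a carboxylic acid would be tolerated where methyl and bromo stand remains open. The compounds also leave open how a plain hydrogen there would compare.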